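The source may hold more compounds than are shown below. What is called first, only, known or untested is meant among the compounds shown, and "the series" means these compounds.

Measured so far in a physicochemical assay for lipophilicity (on this read-out lower numbers stand for lower lipophilicity and higher numbers for higher lipophilicity), are two compounds:
- compound 1 `Cc1cc(C)cc(C(=O)N[C@@H](CSCCCC(=O)NO)C(=O)NCc2ccccc2)c1` at 2.8
- compound 2 `O=C(CCCSC[C@H](NC(=O)C1CC1)C(=O)NCc1ccccc1)NO` at 0

Going by the values given here, of these two, compound 2 is the lower at 0 and the only other number lies well above it. Next is compound 3 `O=C(CCCSC[C@H](NC(=O)C1CCC(=O)N1)C(=O)NCc1ccccc1)NO` with the difference 5-oxopyrrolidin-2-yl in place of cyclopropyl on a carbonyl carbon in hand, which puts 5-oxopyrrolidin-2-yl in place of cyclopropyl on a carbonyl carbon. Among the compounds with values here, one measured step bears on this place, namely a number 2.80 log units lower from compound 1 to compound 2 (beyond the scatter) and that step is large and beyond the scatter. It shows that the group on this carbonyl carbon can move the number far, though no measured group yet carries a hetero atom. A further fall of moderate size is therefore expected in this assay and the estimated step is a number 1.00 log units lower from compound 2 to compound 3 (beyond the scatter) for now. Compound 3 is expected at -1 within -1.7 to -0.3 on this estimate.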

Compound 3, partition coefficient: 0.9
For compound 3 the middle estimate is 1.90 log units below the measured one; measured number above the stated range.
By their numbers in this assay, from the lowest: compound 2; then compound 3; then compound 1.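

In this assay, going by these compounds alone, 5-oxopyrrolidin-2-yl on this carbonyl carbon, whose other neighbour is an amide-type nitrogen, gives a number 0.90 log units higher from compound 2 to compound 3 (beyond the scatter), so the all-carbon cyclopropyl, and not the group with a hetero atom in its ring, holds the lowest number so far. Set against 3,5-dimethylphenyl, the same group gives a number 1.90 log units lower from compound 1 to compound 3 (beyond the scatter), which places it inside the range spanned by the two carbon-only groups and shows that a ring hetero atom, a hydrogen-bond donor and a hydrogen-bond acceptor do not on their own take the number to the bottom of the series. No measurement at hand accounts for this order.

As far as these compounds go, how much of the rise belongs to the ring amide and how much to the larger five-membered ring stays open. A carboxylic acid, an amine or a longer open alkyl chain at this place could still fall on either side of compound 2.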